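A few compounds are considered here, and "the series" means these few. Any claim that something is new, unique, unknown or untested is made for them only; others in the source may bear on it.

Three compounds share one core and differ only in the group attached to a sulfur in the side chain, or in a substituent on that group. Compound 1 `Cn1c(-c2ccc(NC(=O)CSc3nc4cc(Cl)ccc4o3)cc2)nc(-c2ccccc2)c1-c1ccccc1` carries a 5-chloro-1,3-benzoxazol-2-yl there; in a functional assay on HT-29 cells (Homo sapiens) for cytotoxicity, read by MTT assay, with a stated time of 24 h, tested at 16 ug/mL (on this read-out higher numbers stand for a stronger effect at the one concentration tested and lower numbers for a weaker effect), compound 1 gives 42.5%. Compound 2 `Cc1ccc2oc(SCC(=O)Nc3ccc(-c4nc(-c5ccccc5)c(-c5ccccc5)n4C)cc3)nc2c1` has methyl in place of chloro on an aromatic carbon, and compound 2 gives 37.7%, a change of a number 4.8 percentage points lower from compound 1 to compound 2 (within the scatter). Compound 3 `Cn1nnnc1SCC(=O)Nc1ccc(-c2nc(-c3ccccc3)c(-c3ccccc3)n2C)cc1` carries a 1-methyl-1H-tetrazol-5-yl on the sulfur; compound 3 gives 72.5%, the highest of the three numbers, reached through a number 30 percentage points higher from compound 1 to compound 3 (beyond the scatter) and a number 34.8 percentage points higher from compound 2 to compound 3 (beyond the scatter), both beyond the scatter.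

Compound 4 `Cc1nnc(SCC(=O)Nc2ccc(-c3nc(-c4ccccc4)c(-c4ccccc4)n3C)cc2)s1` takes one further step: 5-methyl-1,3,4-thiadiazol-2-yl in place of 1-methyl-1H-tetrazol-5-yl on a sulfur. The ring that leaves is a five-membered aromatic ring with 4 hetero atoms; the ring that enters is also five-membered, with 3 hetero atoms, one of them sulfur. The two measured steps that bear on this exchange both swapped the group on the sulfur and both favoured the tetrazolyl over either benzoxazolyl. Compound 4 keeps a single five-membered ring but not the same one, so a moderate loss against compound 3 is expected. Compound 4 is expected to give 58%, in the range 38% to 78%. The expected step is therefore a number 14.5 percentage points lower from compound 3 to compound 4 (beyond the scatter).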

Compound 4, a percentage reported as activity, at one concentration (the size of the read-out at that concentration, not a potency): 83.3%
Compound 4: middle estimate off by 25.3 percentage points, on the low side, outside the stated range (above it).
By their numbers in this assay, from the lowest: compounds 2 and 1 (each within the scatter of the next); then compound 3; then compound 4.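

In this assay the exchange on this sulfur gives a number 10.8 percentage points higher from compound 3 to compound 4 (beyond the scatter) and shows that the 1-methyl-1H-tetrazol-5-yl is not the highest-scoring group shown here: a five-membered aromatic ring with the same count of heavy atoms but fewer hetero atoms, one of them sulfur, goes further. Against the two benzoxazolyl groups the gain is larger, with a number 45.6 percentage points higher from compound 2 to compound 4 (beyond the scatter) and a number 40.8 percentage points higher from compound 1 to compound 4 (beyond the scatter), so both groups built on a single five-membered ring now stand above both benzoxazolyl groups, and no compound shown goes against this. Nothing measured here explains why the thiadiazolyl group gives the higher number.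

As far as these compounds go, it remains open whether the single five-membered ring is what matters, since a six-membered ring such as pyridyl, or an open group such as a carboxylic acid or an amine on a longer chain, would test that idea at this sulfur. Each number also comes from one concentration, so these results give no potency and do not show whether the same order would hold in other cells.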